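Swapping Fluoro for Chloro Where Both Parents Hit the Limit

A few compounds are considered here, and "the series" means these few. Any claim that something is new, unique, unknown or untested is made for them only; others in the source may bear on it.

Compound 1 `C/C(=N\Nc1nc(-c2ccc(Cl)cc2)cs1)c1sc(C)nc1C`: in a toxicity assay on THP-1 cells (Homo sapiens) for cytotoxicity, read by MTT assay (a lower number here means a stronger inhibitor of growth, a higher number a weaker inhibitor of growth), compound 1 gives > 100 ug/mL, a limit of the assay rather than a number.
Compound 2 `C/C(=N\Nc1nc(-c2ccc(F)cc2)cs1)c1sc(-c2ccccc2)nc1C`: in this assay compound 2 gives > 100 ug/mL, again a limit and not a number.

Among the compounds with values here, compound 2 therefore stands nowhere in particular among the numbers: it sits at the limit of > 100 ug/mL in this assay, at which 2 of the 2 values shown sit, and compound 1 sits there with it, so no order between the two can be read and no measured step exists to lean on.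

Compound 3 `C/C(=N\Nc1nc(-c2ccc(Cl)cc2)cs1)c1sc(-c2ccccc2)nc1C` differs from compound 2 by chloro in place of fluoro on an aromatic carbon. With the shared core and every other part of the molecule kept, and with both measured members of this series resting at the same limit, the expected step that the limit leaves unreadable from compound 2 to compound 3 is none beyond the scatter. Compound 3 is estimated to show 150 ug/mL, with a range from 60 ug/mL to 400 ug/mL, most likely reported once more only as a limit.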

Compound 3, concentration for 50% growth inhibition: > 100 ug/mL
Compound 3: no number, only a limit; the forecaster's own chance of this, stated with the estimate: 85%; the middle value lies beyond the limit too.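

No step among compound 1, compound 2 and compound 3 can be read in this assay, since all three rest at one limit: the limit of > 100 ug/mL in this assay, at which 3 of the 3 values shown sit.

The compounds shown leave open whether chloro or fluoro, or phenyl or methyl, makes any difference to the growth inhibition read in this assay at all.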